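The compounds below may be only part of what the source reports. "The series", "measured", "known", "first", "only" and "open" are said of these compounds alone.

Working notes on the series.

Compound 1 `O=C(O)CC(Cc1nc2cc(F)ccc2[nH]1)c1ccc(Cl)cc1` gives in an assay on isolated protein for inhibition of protein kinase C zeta type (Homo sapiens), read by 33P incorporation, tested at 50 uM (a higher number here means a stronger effect of the compound at the concentration tested, a lower number a weaker effect), a read-out of 0%. Compound 2 `Cc1ccc2[nH]c(CC(CC(=O)O)c3ccc(Cl)cc3)nc2c1` gives in this assay a read-out of 0%. Among the compounds with values here, the one measured step, no change at the digits printed from compound 1 to compound 2 (within the scatter), changes methyl in place of fluoro on an aromatic carbon and leaves the read-out flat within the scatter. Compound 2 therefore stands level with compound 1 at the digits shown, both at the bottom of the scale, with no indication of order between them.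

Compound 3 `O=C(O)CC(Cc1nc2cc(C(=O)O)ccc2[nH]1)c1ccc(Cl)cc1` is the next unmeasured member. It differs from compound 2 by carboxy in place of methyl on an aromatic carbon. Within the data shown here, the only step known, from compound 1 to compound 2, touches the same aromatic carbon and was flat; no measured step involves carboxy. On the evidence available, the step from compound 2 to compound 3 is expected to stay within the scatter, as a number 2 percentage points higher from compound 2 to compound 3 (within the scatter). Compound 3 is estimated to give in this assay about 2%, with an expected range from -8% to 15%.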

Compound 3, a percentage reported as inhibition, at one concentration (the size of the read-out at that concentration, not a potency): 0%
Compound 3: the middle estimate sits 2 percentage points above what was measured, within the range that was stated.
By their numbers in this assay, from the lowest: compounds 1, 2 and 3 (each within the scatter of the next).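

Carboxy in place of methyl gives no change at the digits printed from compound 2 to compound 3 (within the scatter) in this assay, and carboxy in place of fluoro gives no change at the digits printed from compound 1 to compound 3 (within the scatter). This aromatic carbon has now carried a group with a hydrogen-bond donor and a hydrogen-bond acceptor as well as methyl and fluoro, and none of the three lifts the read-out off the bottom of the scale. Nothing measured alongside these read-outs bears on why the change leaves the result flat.

Going by these compounds, whether an amine or a methoxy group on this aromatic carbon, or an amide in place of the carboxylic acid on the chain, would give a read-out above the bottom of the scale stays open. With all three compounds at the same read-out, the series gives no order among methyl, fluoro and carboxy.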